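A Second Methyl on the Saturated Ring

The source may hold more compounds than are shown below. What is called first, only, known or untested is meant among the compounds shown, and "the series" means these compounds.

Compound 1, `CC1CCC(NC(=O)c2cc3c(F)cc(F)cc3[nH]2)CC1`: in a physicochemical assay for solubility, measured as thermodynamic solubility, with a stated time of 24 h, at pH 6.8 (a lower number here means a less soluble compound, a higher number a more soluble compound), compound 1 gives < 4000 nM, which is a limit of the assay, not a number.
Compound 2, `CC1CCC(NC(=O)c2cc3c(F)cc(Cl)cc3[nH]2)CC1`: in this assay compound 2 gives < 4000 nM, likewise a limit rather than a number.

Compound 1 thus stands only at a limit, with no exact figure. For the measured compounds named here, the single measured step, a step that the two limits leave unreadable from compound 1 to compound 2, cannot be sized because of the limit of < 4000 nM in this assay, at which 2 of the 2 values shown sit. Compound 3, `CC1(C)CCC(NC(=O)c2cc3c(F)cc(F)cc3[nH]2)CC1`, differs from compound 1 by methyl in place of hydrogen on a saturated ring carbon. Going by the values given here, no measured step covers this kind of change, so nothing shows which way it goes; compound 3 is expected to remain at the limit, an estimated step that the limit leaves unreadable from compound 1 to compound 3. Compound 3 is expected to give about 2000 nM, in the range 400 nM to 4000 nM.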

Compound 3, solubility: < 4000 nM
Compound 3: a limit, no number; the forecaster's own chance of this, stated with the estimate: 85%; the middle value does not contradict the limit.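

The step from compound 1 to compound 3 cannot be read, since both compounds stand at a limit in this assay rather than at a number: the limit of < 4000 nM in this assay, at which 3 of the 3 values shown sit.

On these data alone, whether methyl in place of hydrogen on a saturated ring carbon changes this read-out at all, and in which direction, stays open.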